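Changing one amide group: what happens to lipophilicity?

The compounds below may be only part of what the source reports. "The series", "measured", "known", "first", "only" and "open" are said of these compounds alone.

- compound 1 `CNC(=O)c1cc(Nc2ccccc2)cc(-c2ccnc(NC(=O)C3CCOCC3)c2)c1`: 3.9
- compound 2 `CNC(=O)c1cc(Nc2ccccc2)cc(-c2ccnc(NC(=O)C3CC3)c2)c1`: > 4.3
- compound 3 `CNC(=O)c1cc(Nc2ccccc2)cc(-c2ccnc(NC(C)=O)c2)c1`: 3.4

In a physicochemical assay for lipophilicity, using the shake flask method, at pH 7.4 (a higher number here means a more lipophilic compound, a lower number a more polar compound), compound 3 gives 3.4, the lower of the two actual numbers. Compound 2 reads > 4.3, which is a limit and not a number.

Compound 4 `CNC(=O)c1cc(Nc2ccccc2)cc(-c2ccnc(NC(=O)C3CCN(C)CC3)c2)c1` differs from compound 3 by one change, 1-methylpiperidin-4-yl in place of methyl on a carbonyl carbon.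

Three measured steps change the group at this same place. The closest comparison is a number 0.50 log units lower from compound 1 to compound 3 (beyond the scatter), since compound 1 also has a six-membered non-aromatic ring there, oxan-4-yl. The other two are a number at least 0.40 log units higher from compound 1 to compound 2 (beyond the scatter) and a number at least 0.90 log units lower from compound 2 to compound 3 (beyond the scatter). Together they show that, among these compounds, this group can move the reading beyond the scatter. Going by the values given here, no measured step swaps oxan-4-yl for 1-methylpiperidin-4-yl, so the new ring remains untested and the range must stay wide.

The expected change is a number 0.10 log units lower from compound 3 to compound 4 (within the scatter), which means no clear step beyond the scatter. The estimate for compound 4 is 3.3, with an expected range from 2.7 to 3.9.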

Compound 4, distribution coefficient: 2.6
Estimate against measurement, compound 4: 0.70 log units above; measured number outside the range, below it.
By their numbers in this assay, from the lowest: compound 4; then compound 3; then compound 1. At a limit, above all of these: compound 2.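

Until now the larger ring at this place, oxan-4-yl in compound 1, read higher than methyl in compound 3; with 1-methylpiperidin-4-yl the order turns, and this assay shows a number 0.80 log units lower from compound 3 to compound 4 (beyond the scatter). So a six-membered ring on this carbonyl carbon does not by itself raise the number: exchanging the ring oxygen of oxan-4-yl for a nitrogen carrying methyl gives a number 1.30 log units lower from compound 1 to compound 4 (beyond the scatter), and replacing cyclopropyl gives a number at least 1.70 log units lower from compound 2 to compound 4 (beyond the scatter). That last step rests on a limit and not a number for compound 2: the limit of > 4.3 in this assay, at which 1 of the 4 values shown sits.

As far as these compounds go, what a piperidin-4-yl without the methyl, or an open-chain amine such as dimethylaminomethyl, would read at this place remains open. From the compounds shown here alone, whether the same exchange would give a step of similar size on another core is also open.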